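Opening the Dioxolane Side Chain: Expectations for Compound 4

The source may report more compounds than this note shows. Statements on the series, on what has been measured and on what is new or still open speak of the compounds shown alone.

Measured in a toxicity assay on HEK-293T cells (Homo sapiens) for cytotoxicity, read by MTT assay, with a stated time of 72 h; a higher number here means a weaker inhibitor, a lower number a stronger inhibitor:
- Compound 1 `O=C1c2c[n+]([O-])c3ccccc3c2C(=O)c2c1c1ccccc1n2Cc1cn([C@H]2O[C@H](CO)[C@@H](O)[C@H]2O)nn1`: 1370 nM
- Compound 2 `CC1(C)OCC(Cn2cc(Cn3c4c(c5ccccc53)C(=O)c3c[n+]([O-])c5ccccc5c3C4=O)nn2)O1`: 5510 nM
- Compound 3 `CC1(C)OC[C@@H](Cn2cc(Cn3c4c(c5ccccc53)C(=O)c3c[n+]([O-])c5ccccc5c3C4=O)nn2)O1`: 6020 nM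

Compound 3 shares the upper end of these numbers with compound 2, as the comparison shows a 1.1-fold higher number from compound 2 to compound 3 (0.04 log units; within the scatter). Both lie clearly above compound 1, and for compound 3 that gap is a 4.4-fold higher number from compound 1 to compound 3 (0.64 log units; beyond the scatter).

The next compound to be tested is compound 4 `O=C1c2c[n+]([O-])c3ccccc3c2C(=O)c2c1c1ccccc1n2Cc1cn(C[C@@H](O)CO)nn1`. It differs from compound 3 by 1,2-dihydroxyethyl in place of 2,2-dimethyl-1,3-dioxolan-4-yl on a saturated chain carbon bound to an aromatic nitrogen, with 1,2-dihydroxyethyl in place of 2,2-dimethyl-1,3-dioxolan-4-yl on a saturated chain carbon bound to an aromatic nitrogen.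

Within the data shown here, no measured step makes this exact change. The nearest evidence is the pair of steps that replace the 3,4-dihydroxy-5-(hydroxymethyl)oxolan-2-yl group of compound 1 with the dioxolane group, namely a 4.0-fold higher number from compound 1 to compound 2 (0.60 log units; beyond the scatter) and a 4.4-fold higher number from compound 1 to compound 3 (0.64 log units; beyond the scatter). Both are modest and both raise the number. Compound 4 regains hydroxyl groups but not the ring of compound 1, so a partial return towards compound 1 seems likely, and the expected move in this assay is to a lower number. The expected step is a 2.3-fold lower number from compound 3 to compound 4 (0.36 log units; beyond the scatter), which may not clear the scatter by much.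

Compound 4 is estimated at 2600 nM, with an expected range of 1100 nM to 6000 nM.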

Compound 4, half-maximal inhibitory concentration: 2030 nM
Beside the measured number, compound 4's estimate is 1.3-fold (0.11 log units) above it; the measured number falls inside the stated range.
By their numbers in this assay, from the lowest: compounds 1 and 4 (each within the scatter of the next); then compounds 2 and 3 (each within the scatter of the next).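

In this assay, among these compounds, the change from 2,2-dimethyl-1,3-dioxolan-4-yl to 1,2-dihydroxyethyl, on a saturated chain carbon bound to an aromatic nitrogen, gives a measured step for the first time, and it is seen against both dioxolane compounds (a 3.0-fold lower number from compound 3 to compound 4 (0.47 log units; beyond the scatter); a 2.7-fold lower number from compound 2 to compound 4 (0.43 log units; beyond the scatter)). The earlier compounds could not separate the ring of compound 1 from its hydroxyl groups, but the ring-free 2,3-dihydroxypropyl chain stays within the scatter of the 3,4-dihydroxy-5-(hydroxymethyl)oxolan-2-yl group (a 1.5-fold higher number from compound 1 to compound 4 (0.17 log units; within the scatter)), so among these compounds that sugar ring is not needed for the lower numbers. The stereo drawing that separates compounds 2 and 3 does not bear on this step, and nothing shown gives a cause for it.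

The compounds shown leave open whether the free hydroxyl groups themselves matter or only the loss of the dioxolane ring, which a 2,3-dimethoxypropyl chain, or an amine or a carboxylic acid on the same chain, would help to separate. They also leave open whether the opposite configuration at the stereocentre of the 2,3-dihydroxypropyl chain would read the same.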